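The source may report more compounds than this note shows. Statements on the series, on what has been measured and on what is new or still open speak of the compounds shown alone.

In a functional assay on SK-BR-3 cells (Homo sapiens) for cytotoxicity, read by MTT assay, with a stated time of 72 h (on this read-out lower numbers stand for stronger inhibition and higher numbers for weaker inhibition), compound 1 `NCCCNc1c(C(=O)NCc2ccc(F)cc2)nc(Br)c2cccnc12` is recorded as "not determined" (no result reported), which leaves two numbers: compound 2 `CN(C)CCCNc1c(C(=O)NCc2ccc(F)cc2)nc(Br)c2cccnc12` at 1000 nM and compound 3 `N[C@H]1CC[C@H](Nc2c(C(=O)NCc3ccc(F)cc3)nc(Br)c3cccnc23)CC1` at 2000 nM. Among the compounds with values here, the only measured step is a 2.0-fold higher number from compound 2 to compound 3 (0.30 log units; within the scatter), so neither number stands apart. Compound 4 `O=C(NCCCNc1c(C(=O)NCc2ccc(F)cc2)nc(Br)c2cccnc12)c1ccccc1` carries benzamido in place of dimethylamino on a saturated chain carbon, three bonds along the chain from a nitrogen on an aromatic ring. Within the data shown here, that measured step, 4-aminocyclohexyl in place of 3-(dimethylamino)propyl, bears on this change only loosely, and no measured step covers benzamido. No shift beyond the scatter is therefore expected in this assay, and the expected size is a 1.5-fold higher number from compound 2 to compound 4 (0.18 log units; within the scatter). The estimate for compound 4 is 1500 nM, with an expected range from 500 nM to 5000 nM.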

Compound 4, half-maximal inhibitory concentration: 1000 nM
For compound 4 the middle estimate is 1.5-fold (0.18 log units) above the measured one; low and high end bracket the measured number.
By their numbers in this assay, from the lowest: compounds 2, 4 and 3 (each within the scatter of the next).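

In this assay, the step of no change at the digits printed from compound 2 to compound 4 (within the scatter) shows that this place, a saturated chain carbon three bonds along the chain from a nitrogen on an aromatic ring, accepts benzamido with its six-membered aromatic ring without a shift beyond the scatter. Among the compounds shown, dimethylamino is therefore not needed here to hold the number at this level. Nothing available explains this result. The compounds shown leave open whether a sulfonamide or a urea in place of benzamido, or a longer chain, would move the number beyond the scatter.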